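Swapping a chloropyridine sulfonyl for a dichlorophenyl sulfonyl

This account rests on a few compounds, and the source may have more. Where it says the series, first, only, none or still open, it means among the compounds named here.

Compound 1 `N#Cc1ccc(S(=O)(=O)[C@H]2CN(S(=O)(=O)c3ccc(Cl)cn3)C[C@@]2(O)CO)cc1` is the more lipophilic of the two measured compounds: in a physicochemical assay for lipophilicity, at pH 7.4 (on this read-out higher numbers stand for higher lipophilicity and lower numbers for lower lipophilicity), compound 1 gives 3.1, while compound 2 `N#Cc1ccc(O[C@H]2CN(S(=O)(=O)c3ccc(Cl)cn3)C[C@@]2(O)CN)cc1F` gives 2.5 in this assay. Within the data shown here, no single-point steps connect these two. Compound 3 `N#Cc1ccc(S(=O)(=O)[C@H]2CN(S(=O)(=O)c3ccc(Cl)cc3Cl)C[C@@]2(O)CO)cc1` has not yet been measured; it differs from compound 1 in one place: 2,4-dichlorophenyl in place of 5-chloropyridin-2-yl on a sulfonyl sulfur. Starting from the value of compound 1 in this assay, the shift from compound 1 to compound 3 is expected to be a number 1.20 log units higher from compound 1 to compound 3 (beyond the scatter), a rise well beyond the scatter. Compound 3 is therefore estimated at 4.3, within 3.7 to 4.9.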

Compound 3, distribution coefficient: 4.5
Estimate against measurement, compound 3: 0.20 log units below, within the range that was stated.
By their numbers in this assay, from the lowest: compound 2; then compound 1; then compound 3.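

Among these compounds, this is the first single-place step in the set, and it shows that the group on a sulfonyl sulfur whose other neighbour is the sulfonamide nitrogen in a ring strongly affects the reading in this assay, which is a number 1.40 log units higher from compound 1 to compound 3 (beyond the scatter) with the rest of the core of compound 1 unchanged. Nothing shown explains the size of this step.

The compounds shown leave open how much of the step belongs to the second chlorine and how much to the loss of the ring nitrogen, which a 4-chlorophenyl group could separate. They also leave open whether a group such as an amine or a carboxylic acid at this sulfur-bound ring would move the reading the opposite way.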